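A few compounds are considered here, and "the series" means these few. Any claim that something is new, unique, unknown or untested is made for them only; others in the source may bear on it.

Compound 1 `COc1ccc(C2(NC(=O)c3c(OC)cc(C(F)(F)F)cc3SC)CCCN(C)C2)cc1`: 170 nM
Compound 2 `COc1cc(C(F)(F)F)cc(SC)c1C(=O)NC1(c2cccc(F)c2)CCCN(C)C1`: 48 nM
Compound 3 `COc1cc(C(F)(F)F)cc(SC)c1C(=O)NC1(c2ccc(F)cn2)CCCN(C)C1`: 180 nM

In an assay on cells for inhibition of sodium- and chloride-dependent glycine transporter 1 (Homo sapiens) (on this read-out lower numbers stand for an effect already at smaller amounts and higher numbers for an effect only at larger amounts of compound), compound 3 gives the highest of the three numbers shown, though compound 1 lies within the scatter of it, and only the step of a 3.8-fold higher number from compound 2 to compound 3 (0.57 log units; beyond the scatter) reaches beyond the scatter. Compound 4 `COc1cc(C(F)(F)F)cc(SC)c1C(=O)NC1(c2cnccn2)CCCN(C)C1` carries pyrazin-2-yl in place of 5-fluoropyridin-2-yl on a saturated ring carbon. Among the compounds with values here, no measured step exchanges one aromatic ring holding a hetero atom for another; the nearest guides are the step of a 1.1-fold higher number from compound 1 to compound 3 (0.02 log units; within the scatter), which stayed within the scatter, and the modest step of a 3.5-fold lower number from compound 1 to compound 2 (0.55 log units; beyond the scatter). A step of at most modest size is therefore expected in this assay, with no clear direction. Compound 4 is expected to give about 250 nM, between 100 nM and 650 nM, which means an expected step of a 1.4-fold higher number from compound 3 to compound 4 (0.14 log units; within the scatter).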

Compound 4, half-maximal effective concentration: 1670 nM
Beside the measured number, compound 4's estimate is 6.7-fold (0.82 log units) below it, and the stated range ends below it.
By their numbers in this assay, from the lowest: compound 2; then compounds 1 and 3 (each within the scatter of the next); then compound 4.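

In this assay, this position proves sensitive to the choice of aromatic ring: pyrazin-2-yl gives a 9.3-fold higher number from compound 3 to compound 4 (0.97 log units; beyond the scatter), although a 1.1-fold higher number from compound 1 to compound 3 (0.02 log units; within the scatter) had suggested that a hetero atom in the ring changes little. Pyrazin-2-yl also compares poorly with the other two rings, with a 9.8-fold higher number from compound 1 to compound 4 (0.99 log units; beyond the scatter) and a 35-fold higher number from compound 2 to compound 4 (1.54 log units; beyond the scatter). Nothing measured here accounts for this loss.

From the compounds shown here alone, the change adds a second ring nitrogen and removes the fluorine at once, so the share of each stays open. An unsubstituted pyridin-2-yl group at this position could separate the two.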